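Trimming the allyl chain of compound 2 to methyl

The source may hold more compounds than are shown below. What is called first, only, known or untested is meant among the compounds shown, and "the series" means these compounds.

Going by the values given here, in a functional assay on MCF7 cells (Homo sapiens) for cytotoxicity, read by CCK-8 assay, with a stated time of 72 h (a lower number here means a stronger inhibitor, a higher number a weaker inhibitor), compound 2 (`C=CCn1c(=O)/c(=C\c2ccccc2Cl)[nH]c(=O)/c1=C\c1ccccc1OC`) gives 4700 nM, the lowest number of the three measured so far. Compound 1 (`C=CCn1c(=O)/c(=C\c2cccc(F)c2)[nH]c(=O)/c1=C\c1ccccc1OC`) gives 13700 nM, and compound 3 (`C=CCn1c(=O)/c(=C\c2cc(Br)ccc2F)[nH]c(=O)/c1=C\c1ccccc1OC`) gives 28100 nM. All three carry an allyl chain on the shared core and differ in a single aromatic group.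

Compound 4 (`COc1ccccc1/C=c1\c(=O)[nH]/c(=C/c2ccccc2Cl)c(=O)n1C`) keeps the 2-chlorophenyl group of compound 2 and alters the chain instead: hydrogen in place of vinyl on a saturated chain carbon bound to an aromatic nitrogen. In words, this is hydrogen in place of vinyl on a saturated chain carbon bound to an aromatic nitrogen, which turns allyl into methyl.

Among the compounds with values here, no measured step touches this chain, so the data give no direct sign of direction. The three available steps all swap the aromatic group: a 2.9-fold lower number from compound 1 to compound 2 (0.46 log units; beyond the scatter), a 2.1-fold higher number from compound 1 to compound 3 (0.31 log units; beyond the scatter) and a 6.0-fold higher number from compound 2 to compound 3 (0.78 log units; beyond the scatter). Each is modest, and they show only how far one change has moved the numbers in this small set. A step of similar size is therefore expected, and upward is the likelier direction, since compound 2 at 4700 nM already sits lowest. The expected step is a 2.1-fold higher number from compound 2 to compound 4 (0.33 log units; beyond the scatter). For compound 4 the estimated value is 10000 nM, with an expected range from 3000 nM to 30000 nM.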

Compound 4, half-maximal inhibitory concentration: 200 nM
The estimate for compound 4 lay 50-fold (1.70 log units) above the measured number; the whole stated range lies above it.
By their numbers in this assay, from the lowest: compound 4; then compound 2; then compound 1; then compound 3.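

The chain on the aromatic nitrogen, left unchanged in compounds 1 to 3, turns out to be a sensitive place: in this assay, with the 2-chlorophenyl group held fixed, turning allyl into methyl gives the largest step seen so far (a 24-fold lower number from compound 2 to compound 4 (1.37 log units; beyond the scatter)). That step clearly exceeds even the widest swap of aromatic groups (a 6.0-fold higher number from compound 2 to compound 3 (0.78 log units; beyond the scatter)), so in this small set the chain moves the number further than any of the aromatic changes shown. The compounds shown give no measurement that explains why removing the vinyl part of the chain has such a large effect.

A single pair cannot show whether methyl itself is special, or whether an ethyl chain, a propyl chain or a plain hydrogen on that nitrogen would give a similarly low number, and a chain ending in an amine or a carboxylic acid would test the position further. From the compounds shown here alone, it is also open whether the same change from allyl to methyl would bring a step of this size with the 3-fluorophenyl group of compound 1 or the 5-bromo-2-fluorophenyl group of compound 3.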